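This account rests on a few compounds, and the source may have more. Where it says the series, first, only, none or still open, it means among the compounds named here.

In a functional assay on the whole organism for inhibition, with Rattus norvegicus as the target (a higher number here means that more compound is needed for the effect, a lower number that less compound is needed), three compounds have been measured so far.
Compound 1 `CC1CC/C(=N\Nc2ccccc2I)c2ncc(C(=O)O)c(=O)n21` gives only a limit, > 1000 umol/kg.
Compound 2 `CC1CC/C(=N\Nc2cccc(I)c2)c2ncc(C(=O)O)c(=O)n21` gives 1000 umol/kg.
Compound 3 `COc1ccc(N/N=C2\CCC(C)n3c2ncc(C(=O)O)c3=O)cc1` gives 7.6 umol/kg.

Compound 3 stands lowest of the two numbers. Its nearest neighbour is compound 2, separated by the step of a 130-fold lower number from compound 2 to compound 3 (2.12 log units; beyond the scatter); the step of an at least 130-fold lower number from compound 1 to compound 3 (2.11 log units; beyond the scatter) runs from the compound sitting at the limit (the limit of > 1000 umol/kg in this assay, at which 1 of the 3 values shown sits).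

Compound 4 `Cc1ccccc1N/N=C1\CCC(C)n2c1ncc(C(=O)O)c2=O` differs from compound 3 by 2-methylphenyl in place of 4-methoxyphenyl on an amine nitrogen. For the measured compounds named here, the steps that bear on this change are an at least 130-fold lower number from compound 1 to compound 3 (2.11 log units; beyond the scatter) and a 130-fold lower number from compound 2 to compound 3 (2.12 log units; beyond the scatter), both large and both gained when 4-methoxyphenyl entered in place of an iodophenyl, while a number no higher from compound 1 to compound 2 (the limit leaves the size open) is of unreadable size. Giving up the 4-methoxyphenyl for 2-methylphenyl is therefore expected to raise the number in this assay clearly, by a 39-fold higher number from compound 3 to compound 4 (1.60 log units; beyond the scatter). For compound 4 the estimate is 300 umol/kg, expected to lie between 40 umol/kg and 1000 umol/kg.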

Compound 4, dose for 50% inhibition: > 100 umol/kg
Compound 4: only a limit was reported; the forecaster's own chance of this, stated with the estimate: 30%; the middle value lies beyond the limit too.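

In this assay, 2-methylphenyl on the amine nitrogen does not hold the low number of the 4-methoxyphenyl: the change gives an at least 13-fold higher number from compound 3 to compound 4 (1.11 log units; beyond the scatter). Compound 4 is reported only as a limit: the limit of > 100 umol/kg in this assay, at which 1 of the 4 values shown sits.

The steps from compound 1 and compound 2 to compound 4 cannot be read, so methyl cannot be ranked against either iodo placement. The compounds shown also leave open whether the large step follows the loss of the methoxy or the arrival of the methyl, and a plain phenyl on the amine nitrogen would help separate the two.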